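The compounds below may be only part of what the source reports. "The series", "measured", "known", "first", "only" and "open" are said of these compounds alone.

Three compounds share one core and differ only in the group attached to it. Compound 1 `CC(C)Cc1nc(N)c2nn(-c3ccccc3)cc2n1` carries an isobutyl group and gives 13% in an assay on CHO cells for displacement of a labelled ligand from adenosine receptor A3 (Homo sapiens), read by scintillation counting, tested at 1 uM; on this read-out higher numbers stand for more inhibition at the one concentration tested (going by the name of the read-out) and lower numbers for less inhibition. Compound 2 `Cc1ccc(Cc2nc(N)c3nn(-c4ccccc4)cc3n2)cc1` carries a 4-methylbenzyl group, and in this assay compound 2 gives 39%. Compound 3 `Nc1nc(/C=C/c2ccccc2)nc2cn(-c3ccccc3)nc12` carries a 2-phenylethenyl group, and in this assay compound 3 gives 25%. Compound 2 therefore stands highest of the three, with both its steps to the others beyond the scatter: a number 26 percentage points higher from compound 1 to compound 2 (beyond the scatter) and a number 14 percentage points lower from compound 2 to compound 3 (beyond the scatter).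

Compound 4 `Nc1nc(CCc2ccc(O)cc2)nc2cn(-c3ccccc3)nc12` has not yet been measured. The change from compound 2 is 4-hydroxybenzyl in place of 4-methylphenyl on a saturated chain carbon bound to an aromatic carbon. The step that bears most directly on it is a number 26 percentage points higher from compound 1 to compound 2 (beyond the scatter), which shows that a six-membered aromatic ring at this place helps compared with a branched chain; the step of a number 14 percentage points lower from compound 2 to compound 3 (beyond the scatter) shows that lengthening the link between ring and core costs a modest amount. Since the new group both keeps the ring and lengthens the link, a modest drop is expected, a number 9 percentage points lower from compound 2 to compound 4 (within the scatter), giving an estimated 30% for compound 4, within a range from 10% to 52%.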

Compound 4, a percentage reported as inhibition, at one concentration (the size of the read-out at that concentration, not a potency): 37%
For compound 4 the middle estimate is 7 percentage points below the measured one; the range from low to high includes it.
By their numbers in this assay, from the lowest: compound 1; then compound 3; then compounds 4 and 2 (each within the scatter of the next).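

In this assay, the 4-hydroxybenzyl group brings an oxygen, with a hydrogen-bond donor and acceptor that 4-methylphenyl lacks, yet the reading shows no real change: a number 2 percentage points lower from compound 2 to compound 4 (within the scatter). Within the data shown here, this is the first sign that this place on a saturated chain carbon accepts a group carrying oxygen without losing the advantage over the isopropyl end of the chain, seen as a number 24 percentage points higher from compound 1 to compound 4 (beyond the scatter). No measurement shown accounts for the absence of a change at this place. Whether the hydroxyl itself matters stays open, since the compounds shown include no 2-phenylethyl group without it on the same chain. Nor do they show whether a methoxy group, an amine or a carboxylic acid in place of the hydroxyl would read the same.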